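The compounds below may be only part of what the source reports. "The series", "measured", "known", "first", "only" and "open" are said of these compounds alone.

Working notes on the series. In a functional assay on Sf9 cells for antagonist activity at histamine H2 receptor (Homo sapiens), with stated times of 2 min and 20 min (on this read-out lower numbers stand for lower potency and higher numbers for higher potency (the scale is a negative logarithm)), compound 1 `N/C(=N\C(=O)CC(c1ccccc1)c1ccccc1)NCCCc1ccccc1` gives 5.89, the lowest of the two numbers recorded so far. Among the compounds with values here, the only other measured member, compound 2 `CC(CC(=O)/N=C(\N)NCCCc1ccc(CN(C)C)o1)c1ccccc1`, differs from it in more than one place and gives 6.52 in this assay, a number higher than that of compound 1 by a margin beyond the usual scatter; no single step connects the two, so the pair shows only that a different end group on the chain can go with a higher number.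

Compound 3 `N/C(=N\C(=O)CC(c1ccccc1)c1ccccc1)NCCCc1ncc[nH]1` is the next member to be measured in this assay. It differs from compound 1 in one place: 1H-imidazol-2-yl in place of phenyl on a saturated chain carbon, three bonds along the chain from an amine nitrogen. The change keeps the shared core and the chain length of compound 1, exchanging only the terminal ring. For this change the step of a number 0.91 log units higher from compound 1 to compound 3 (beyond the scatter) is expected to be upward and beyond the scatter. The estimate for compound 3 in this assay is 6.8, with a range from 6.1 to 7.5.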

Compound 3, negative logarithm of the antagonist equilibrium constant: 6.13
Compound 3: the middle estimate sits 0.67 log units above what was measured; measured number inside the range.
By their numbers in this assay, from the lowest: compounds 1 and 3 (each within the scatter of the next); then compound 2.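

With 1H-imidazol-2-yl in place of phenyl on a saturated chain carbon, three bonds along the chain from an amine nitrogen, the series gains its first single-change step, a number 0.24 log units higher from compound 1 to compound 3 (within the scatter) in this assay. At this position, a five-membered aromatic ring with 2 hetero atoms and a six-membered aromatic ring of carbon only therefore give numbers that cannot be told apart on this read-out. Nothing in the available data accounts for this result.

Open, as far as these compounds go, is whether another terminal group on the same chain, such as pyridin-2-yl or 1H-imidazol-4-yl, would give a step beyond the scatter. Also open, from the compounds shown here alone, is whether a longer chain would change the comparison between the phenyl and 1H-imidazol-2-yl ends.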